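Replacing the selenium group of compound 3 with 2-aminoethoxy

The source may hold more compounds than are shown below. What is called first, only, known or untested is meant among the compounds shown, and "the series" means these compounds.

compound 1 `COc1ccc(N(C)c2nc(C)nc3ccccc23)cc1[Se]C` gives 10 nM
compound 2 `COc1ccc(N(C)c2nc(C)nc3ccccc23)cc1C(=O)OCCCC[Se]C#N` gives 554 nM
compound 3 `COc1ccc(N(C)c2nc(C)nc3ccccc23)cc1[Se]C#N` gives 52 nM

In a functional assay on MDA-MB-231 cells (Homo sapiens) for inhibition, read by MTT assay, with a stated time of 48 h (on this read-out lower numbers stand for stronger inhibition and higher numbers for weaker inhibition), compound 3 at 52 nM stands second highest of the three numbers. Compound 4 `COc1ccc(N(C)c2nc(C)nc3ccccc23)cc1OCCN` is still unmeasured and carries a group of 4 heavy atoms (2 carbon, 1 nitrogen, 1 oxygen; no ring) in place of a group of 3 heavy atoms (1 carbon, 1 nitrogen, 1 selenium; no ring), on an aromatic carbon with no selenium left in the molecule. The measured steps bear on this change only indirectly. Cyano in place of methyl on a selenium gave a 5.2-fold higher number from compound 1 to compound 3 (0.72 log units; beyond the scatter) as a modest step. Compound 2, the one measured chain at this place, gave a 55-fold higher number from compound 1 to compound 2 (1.74 log units; beyond the scatter) as a large step, and an 11-fold lower number from compound 2 to compound 3 (1.03 log units; beyond the scatter) was large too. Within the data shown here, no measured compound lacks selenium at this place, so the size of the new step is poorly fixed. Resting on those steps, a modest move to a higher number is expected in this assay and is estimated as a 3.8-fold higher number from compound 3 to compound 4 (0.59 log units; beyond the scatter) with wide uncertainty. For compound 4 the estimated value is 200 nM with an expected range from 40 nM to 1000 nM in this read-out.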

Compound 4, half-maximal inhibitory concentration: 682 nM
The estimate for compound 4 lay 3.4-fold (0.53 log units) below the measured number, within the range that was stated.
By their numbers in this assay, from the lowest: compound 1; then compound 3; then compounds 2 and 4 (each within the scatter of the next).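

In this assay, compound 4 is the only compound shown with no selenium at this place on the aromatic carbon, and exchanging the selenium group of compound 3 for 2-aminoethoxy gives (a 13-fold higher number from compound 3 to compound 4 (1.12 log units; beyond the scatter)), a large step. The gap to the methyl-bearing selenium group of compound 1 is wider, at (a 68-fold higher number from compound 1 to compound 4 (1.83 log units; beyond the scatter)). The short 2-aminoethoxy group and the far longer selenium-bearing ester chain stand level, with (a 1.2-fold higher number from compound 2 to compound 4 (0.09 log units; within the scatter)), so at this place neither the presence of selenium nor chain length alone separates these two compounds.

Nothing available here accounts for these steps. Open, as far as these compounds go, is whether a methylthio group, a plain ethoxy group or a longer aminoalkoxy chain at this place would come closer to compound 1 or stay level with compound 4.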